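Anilinonicotinoyl sulfonohydrazides: antiproliferative read-out, notes

The source may report more compounds than this note shows. Statements on the series, on what has been measured and on what is new or still open speak of the compounds shown alone.

Compound 1 `CC(=O)Nc1ccc(S(=O)(=O)NNC(=O)c2cccnc2Nc2ccc(Cl)cc2)cc1` bears a 4-acetamidophenyl group on the sulfonyl sulfur of the hydrazide. In a functional assay on SK-MEL-5 cells (Homo sapiens) for antiproliferative activity (on this read-out higher numbers stand for lower toxicity in this test and lower numbers for higher toxicity in this test), compound 1 gives > 100000 nM, which is a limit of the test and not a number. Compound 2 `O=C(NNS(=O)(=O)c1ccc(F)cc1)c1cccnc1Nc1ccc(Cl)cc1Cl` likewise gives only a limit in this assay, > 100000 nM. Among the compounds with values here, both results sit at the same limit, (the limit of > 100000 nM in this assay, at which 2 of the 2 values shown sit), so no step between measured compounds can be stated. Compound 3 `O=C(NNS(=O)(=O)c1ccc(Cl)cc1Cl)c1cccnc1Nc1ccc(Cl)cc1` is not yet measured; it differs from compound 1 by 2,4-dichlorophenyl in place of 4-acetamidophenyl on a sulfonyl sulfur. Compound 2 already joins a chlorine-bearing aryl sulfonyl group to the shared core and returns a limit, > 100000 nM. The step is therefore expected to be none beyond the scatter, a number no higher from compound 1 to compound 3 (the limit leaves the size open). Compound 3 is expected to give about 100000 nM in this assay, within 30000 nM to 300000 nM, most probably reported again only as a limit.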

Compound 3, concentration lethal to 50% of the cells: 61700 nM
Beside the measured number, compound 3's estimate is 1.6-fold (0.21 log units) above it, and the stated range covers the measured number.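

The sulfonyl sulfur position now shows a response that can be read as a number: in this assay, 2,4-dichlorophenyl in place of 4-acetamidophenyl gives an at least 1.6-fold lower number from compound 1 to compound 3 (0.20 log units; that floor lies within the scatter). On these data alone, the floor of that step lies within the scatter and its upper end remains open, so the change may be small or much larger. Within the data shown here, only one value is a number so far, and the rest remain limits of the test: the limit of > 100000 nM in this assay, at which 2 of the 3 values shown sit.

The compounds shown leave open how an amine, a carboxylic acid or a longer alkyl chain on the sulfonyl sulfur would read in this assay. They also leave open whether a 4-chlorophenyl group there would read like 2,4-dichlorophenyl or return to the limit.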